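The source may hold more compounds than are shown below. What is called first, only, known or untested is meant among the compounds shown, and "the series" means these compounds.

Measured in a functional assay on BXPC-3 cells (Homo sapiens) for cytotoxicity, read by MTT assay; on this read-out lower numbers stand for stronger inhibition and higher numbers for weaker inhibition:
- compound 1 `Oc1ccc(CN(Cc2ccccc2)Cc2ccc(O)c3ncccc23)c2cccnc12`: 7440 nM
- compound 2 `Oc1ccc(CN(Cc2cccs2)Cc2ccc(O)c3ncccc23)c2cccnc12`: 89 nM

Of these two, compound 2 has the lower number, 89 nM. Compound 3 `O=C(O)C1CCC(CN(Cc2ccc(O)c3ncccc23)Cc2ccc(O)c3ncccc23)CC1` has not yet been measured in this assay. It carries 4-carboxycyclohexyl in place of thiophen-2-yl on a saturated chain carbon bound to an amine nitrogen.

Among the measured compounds shown here, only one measured step bears on this change. It sits at the same place and is large, an 84-fold lower number from compound 1 to compound 2 (1.92 log units; beyond the scatter), and it shows that the number can move far with the group held there. For the measured compounds named here, no measured compound carries a carboxy group, so this evidence is indirect. A large step towards a higher number is expected, since thiophen-2-yl leaves.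

The expected change is a 17-fold higher number from compound 2 to compound 3 (1.23 log units; beyond the scatter). For compound 3 the estimate is 1500 nM, with an expected range from 200 nM to 10000 nM.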

Compound 3, half-maximal inhibitory concentration: 4340 nM
Estimate against measurement, compound 3: 2.9-fold (0.46 log units) below, within the range that was stated.
By their numbers in this assay, from the lowest: compound 2; then compounds 3 and 1 (each within the scatter of the next).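

In this assay, replacing thiophen-2-yl with 4-carboxycyclohexyl on a saturated chain carbon bound to an amine nitrogen gives a 49-fold higher number from compound 2 to compound 3 (1.69 log units; beyond the scatter), so the low number of compound 2 does not carry over to this new group. Replacing phenyl with 4-carboxycyclohexyl at the same place gives a 1.7-fold lower number from compound 1 to compound 3 (0.23 log units; within the scatter), which leaves these two groups indistinguishable here; of the three groups shown, only thiophen-2-yl stands apart from the others. Nothing available explains this difference.

The compounds shown leave open whether the sulfur of thiophen-2-yl or its five-membered aromatic ring sets it apart, a question that a furan at this place could address. They also leave open how the carboxylic acid and the cyclohexane ring of 4-carboxycyclohexyl each contribute, which a plain cyclohexyl group could help separate.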